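Sulfonyl for benzyl on the aromatic nitrogen

The source may report more compounds than this note shows. Statements on the series, on what has been measured and on what is new or still open speak of the compounds shown alone.

Measured in an assay on HEK293 cells for displacement of a labelled ligand from 5-hydroxytryptamine receptor 6 (Homo sapiens), read by scintillation counting, with a stated time of 1 h; on this read-out lower numbers stand for stronger inhibition and higher numbers for weaker inhibition:
compound 1 `C#CCNC1CCc2c(OCCCCCN3CCN(c4cccc5c4ccn5Cc4cccc(Cl)c4)CC3)cccc21`: 223 nM
compound 2 `C[C@H](NCc1ccc(OCCCCCN2CCN(c3cccc4c3ccn4Cc3cccc(Cl)c3)CC2)cc1)C(N)=O`: 232 nM

Compound 2 stands at the higher of the two numbers, but its gap to compound 1 lies within the scatter, so the two compounds are not separated. Compound 3 `C[C@H](NCc1ccc(OCCCCCN2CCN(c3cccc4c3ccn4S(=O)(=O)c3ccccc3)CC2)cc1)C(N)=O` differs from compound 2 in one place: phenylsulfonyl in place of 3-chlorobenzyl on an aromatic nitrogen. Among the measured compounds shown here, no measured pair covers this change, and compounds 1 and 2 both carry the 3-chlorobenzyl group, so nothing measured guides the direction. The expected step of a 1.3-fold lower number from compound 2 to compound 3 (0.11 log units; within the scatter) is small and not beyond the scatter. Compound 3 is estimated at 180 nM, with a range from 45 nM to 700 nM.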

Compound 3, inhibition constant: 65 nM
Beside the measured number, compound 3's estimate is 2.8-fold (0.44 log units) above it, within the range that was stated.
By their numbers in this assay, from the lowest: compound 3; then compounds 1 and 2 (each within the scatter of the next).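

The aromatic nitrogen is sensitive to substitution in this assay: phenylsulfonyl in place of 3-chlorobenzyl gives a 3.6-fold lower number from compound 2 to compound 3 (0.55 log units; beyond the scatter) on an otherwise unchanged structure. Compound 1 and compound 2 both carry 3-chlorobenzyl, so they could not show this. Nothing available accounts for the step.

Since the change replaces the linker and removes the chlorine together, the contribution of each remains unresolved. Unsubstituted benzyl or methylsulfonyl on this nitrogen would separate them, and whether the step carries over to the core of compound 1 remains open.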